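Cytotoxicity in HEL cells: from compound 2 to compound 3

The source may hold more compounds than are shown below. What is called first, only, known or untested is meant among the compounds shown, and "the series" means these compounds.

The measured compounds, each with its value in an ADME assay on HEL cells (Homo sapiens) for cytotoxicity, with a stated time of 3 days; a higher number here means that more compound is tolerated, a lower number that less compound is tolerated:
compound 1, `CCC1(Cc2ccccc2)OS(=O)(=O)C=C1OCC(=O)OC`, gives > 400000 nM, a limit of the assay rather than a number.
compound 2, `CC1(Cc2ccccc2)OS(=O)(=O)C=C1OCc1ccccc1`, gives > 400000 nM, again a limit of the assay rather than a number.

Compound 2 thus stands only at a limit in this assay, and it does not stand alone there: the limit of > 400000 nM in this assay, at which 2 of the 2 values shown sit. Among the compounds with values here, with both values shown sitting at the same limit, no order between compound 1 and compound 2 can be read, and no step between them has been worked out.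

The unmeasured compound is compound 3, `CCC1(Cc2ccccc2)OS(=O)(=O)C=C1OCc1ccccc1`. It differs from compound 2 by one change: methyl in place of hydrogen on a saturated chain carbon bound to a saturated ring carbon. Cut one bond further out, the same change reads methyl to ethyl.

Compound 1 already carries this ethyl, alongside a different group on the oxygen, and it sits at the limit too. The step is therefore expected to be none beyond the scatter, as a number no higher from compound 2 to compound 3 (the limit leaves the size open). For compound 3 the expected minimum cytotoxic concentration is 400000 nM, within 200000 nM to 1000000 nM, and most likely this assay will again report only a limit.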

Compound 3, minimum cytotoxic concentration: >= 50000 nM
Compound 3: a limit, no number; the forecaster's own chance of this, stated with the estimate: 85%; the middle value lies beyond the limit too.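

In this assay, compound 3 gives >= 50000 nM, a limit of the assay and not a number. Within the data shown here, compound 1 and compound 2 also stand only at limits, so no step to compound 3 can be read from either. The compounds shown leave open whether methyl to ethyl changes how much compound the cells tolerate.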